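This account rests on a few compounds, and the source may have more. Where it says the series, first, only, none or still open, it means among the compounds named here.

Measured in a functional assay on MCF7 cells (Homo sapiens) for cytotoxicity, read by MTT assay, with a stated time of 96 h; a lower number here means a stronger inhibitor, a higher number a weaker inhibitor:
Compound 1 `COc1cc(C(=O)c2cn(-c3ccccc3)cc2-c2cccc([N+](=O)[O-])c2)cc(OC)c1OC` gives 50 nM
Compound 2 `COc1cccc(-c2cn(-c3ccccc3)cc2C(=O)c2cc(OC)c(OC)c(OC)c2)c1` gives 180 nM

Of these two, compound 2 at 180 nM is the higher number, which makes it the weaker inhibitor of the pair. Compound 3 `COc1ccc(-c2cn(-c3ccccc3)cc2C(=O)c2cc(OC)c(OC)c(OC)c2)cc1` has the same atoms joined differently: 4-methoxyphenyl in place of 3-methoxyphenyl on an aromatic carbon is the change, 4-methoxyphenyl in place of 3-methoxyphenyl on an aromatic carbon. Within the data shown here, only one measured step bears on this, a 3.6-fold higher number from compound 1 to compound 2 (0.56 log units; beyond the scatter) for methoxy in place of nitro, and it does not test moving a methoxy. In this assay a similarly modest change is therefore expected, leaning lower, though without firm support for that direction. The estimate means a 1.8-fold lower number from compound 2 to compound 3 (0.26 log units; within the scatter) as the expected step. For compound 3 the estimated value is 100 nM with an expected range from 25 nM to 350 nM.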

Compound 3, half-maximal inhibitory concentration: 70 nM
Compound 3: middle estimate off by 1.4-fold (0.15 log units), on the high side, and the stated range covers the measured number.
By their numbers in this assay, from the lowest: compounds 1 and 3 (each within the scatter of the next); then compound 2.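

In this assay, putting 4-methoxyphenyl in place of 3-methoxyphenyl gives a 2.6-fold lower number from compound 2 to compound 3 (0.41 log units; beyond the scatter), so at this position on the shared core, moving the methoxy group alone shifts the number beyond the scatter. Putting 4-methoxyphenyl in place of 3-nitrophenyl gives a 1.4-fold higher number from compound 1 to compound 3 (0.15 log units; within the scatter), so a methoxy-bearing ring can match the nitro-bearing one here, depending on where the methoxy sits. Nothing available explains this difference. As far as these compounds go, whether a 4-aminophenyl or 4-chlorophenyl group at this position would keep such numbers remains open.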